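Carboxy in place of nitro: working notes

The source may hold more compounds than are shown below. What is called first, only, known or untested is meant among the compounds shown, and "the series" means these compounds.

Of the compounds shown here, two have measured values so far in a functional assay on MCF7 cells (Homo sapiens) for cytotoxicity, read by sulforhodamine B assay, with a stated time of 48 h, in the presence of a further agent that is not named here; a lower number here means a stronger inhibitor of growth, a higher number a weaker inhibitor of growth. Compound 1 (`Cc1nn(-c2ccccc2)c(Sc2ccc(-c3nc4cc([N+](=O)[O-])ccc4[nH]3)cc2)c1/C=N/NC(N)=O`) gives 100 nM and compound 2 (`Cc1nn(-c2ccccc2)c(Oc2ccc(-c3nc4cc(C(=O)O)ccc4[nH]3)cc2)c1/C=N/Nc1ccccc1`) gives 90 nM. Going by the values given here, compound 1 therefore stands level with the only other measured compound, since the two values lie within the scatter of each other.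

Compound 3 (`Cc1nn(-c2ccccc2)c(Sc2ccc(-c3nc4cc(C(=O)O)ccc4[nH]3)cc2)c1/C=N/NC(N)=O`) keeps the rest of compound 1 and carries carboxy in place of nitro on an aromatic carbon. Among the compounds with values here, no measured pair isolates this change, so the expectation rests on little. Compound 2 also carries 5-carboxy-1H-benzimidazol-2-yl and gives 90 nM, so no step beyond the scatter is expected in this assay.

The expected change is a 1.1-fold higher number from compound 1 to compound 3 (0.04 log units; within the scatter), with no direction favoured. For compound 3 the estimated value is 110 nM, with an expected range of 35 nM to 350 nM.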

Compound 3, concentration for 50% growth inhibition: 60 nM
The estimate for compound 3 lay 1.8-fold (0.26 log units) above the measured number; the range from low to high includes it.
By their numbers in this assay, from the lowest: compounds 3, 2 and 1 (each within the scatter of the next).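

Carboxy in place of nitro on an aromatic carbon now has a measured pair of its own: in this assay the change gives a 1.7-fold lower number from compound 1 to compound 3 (0.22 log units; within the scatter). On the core of compound 1, 5-nitro-1H-benzimidazol-2-yl and 5-carboxy-1H-benzimidazol-2-yl therefore cannot be told apart in this assay, so neither group can be ranked above the other at this position. No measurement of any property of these compounds is available to account for this result.

From the compounds shown here alone, whether this position tolerates other groups equally, or whether growth inhibition depends on having some substituent there at all, remains open. A primary amine, a methyl ester or plain hydrogen on the same carbon, with the rest of compound 1 kept, would test this.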